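The source may report more compounds than this note shows. Statements on the series, on what has been measured and on what is new or still open speak of the compounds shown alone.

Of the compounds shown here, two sharing a common core have so far been measured in an ADME assay on BaF3 cells (Mus musculus) for cytotoxicity; a higher number here means that more compound is needed for the effect, a lower number that less compound is needed. Compound 1 `CNC(=O)c1cccc(-c2cc(Nc3ccc(OC(F)(F)F)cc3)ncn2)c1` returns > 10000 nM, which is a limit of the assay rather than a number. Compound 2 `CCn1ncc2c(Nc3ccc(OC(F)(F)F)cc3)ncnc21` likewise reports > 10000 nM in this assay, again a limit and not a number. Both values rest at the limit of > 10000 nM in this assay, at which 2 of the 2 values shown sit, so compound 2 stands where every shown value stands, and no ordering between compound 2 and compound 1 can be drawn. Compound 3 `FC(F)(F)Oc1ccc(Nc2ncnc3c2cnn3CC2CCOC2)cc1` has not yet been measured in this assay. It differs from compound 2 by oxolan-3-yl in place of methyl on a saturated chain carbon bound to an aromatic nitrogen. For the measured compounds named here, no measured step between compounds is available to guide the size of this change. Because compound 2 returns > 10000 nM, the step is expected to be none beyond the usual scatter a step that the limit leaves unreadable from compound 2 to compound 3. Compound 3 is therefore estimated at 15000 nM, within a range from 5000 nM to 50000 nM, and most likely reported again only as a limit.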

Compound 3, half-maximal effective concentration: > 10000 nM
Compound 3 was reported as a limit; the forecaster's own chance of this, stated with the estimate: 85%; the middle value does not contradict the limit.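

In this assay compound 3 gives > 10000 nM, which is a limit of the assay and not a number. No step can be read between compound 2 and compound 3: the limit of > 10000 nM in this assay, at which 3 of the 3 values shown sit. The compounds shown leave open at what concentration any of them reaches the effect, and whether oxolan-3-yl in place of methyl changes it.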